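Adding a dimethylamino chain to compound 1

The source may report more compounds than this note shows. Statements on the series, on what has been measured and on what is new or still open speak of the compounds shown alone.

Measured so far in an ADME assay on MDBK cells (Bos taurus) for cytotoxicity, read by MTT assay, with a stated time of 96 h; a lower number here means that less compound is tolerated, a higher number that more compound is tolerated:
- Compound 1 `Cc1ccc(/N=N/N(C)c2ccccc2)cc1` gives > 100000 nM
- Compound 2 `CN(/N=N/c1ccccc1)c1ccccc1` gives > 100000 nM
- Compound 3 `Clc1ccc(/N=N/N2CCCC2)cc1` gives > 100000 nM

Compound 1 gives > 100000 nM in this assay and this is a limit, not a number. The whole set stands at that one reading (the limit of > 100000 nM in this assay, at which 3 of the 3 values shown sit). Compound 4 `Cc1ccc(/N=N/N(CCCN(C)C)c2ccccc2)cc1` differs from compound 1 as follows: 2-(dimethylamino)ethyl in place of hydrogen on a saturated chain carbon bound to a nitrogen on an aromatic ring (cut one bond further out, methyl to 3-(dimethylamino)propyl). Among the measured compounds shown here, the one measured step (a step that the two limits leave unreadable from compound 1 to compound 2) concerns a different change and gives no size, so no measured step bears on this chain. A move toward a lower number in this assay is expected, though its size remains uncertain. The expected step is an at least 2.5-fold lower number from compound 1 to compound 4 (0.39 log units; beyond the scatter) and it remains an estimate. For compound 4 the estimate is 40000 nM with 10000 nM to 100000 nM as its expected range.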

Compound 4, half-maximal cytotoxic concentration: > 100000 nM
Compound 4: a limit, no number; the forecaster's own chance of this, stated with the estimate: 35%; at least 2.5-fold (0.39 log units) between middle value and limit.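

In this assay compound 4 gives > 100000 nM, which is a limit and not a number. No step can be read between compound 1 and compound 4. The compounds shown leave open at what concentration any of them becomes cytotoxic: the limit of > 100000 nM in this assay, at which 4 of the 4 values shown sit.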